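The compounds below may be only part of what the source reports. "The series", "measured", "known", "first", "only" and "open" are said of these compounds alone.

Measured compounds: compound 1 `N[C@H]1CC[C@H](CN(C[C@H]2Cc3ccccc3CN2)[C@H]2CCCc3cccnc32)CC1` with 280 nM and compound 2 `NC(=O)NC/C=C\CN(C[C@H]1Cc2ccccc2CN1)[C@H]1CCCc2cccnc21` with 210 nM in a functional assay on CCRF-CEM cells for antagonist activity at C-X-C chemokine receptor type 4 (Homo sapiens), read by calcium flux, with stated times of 25 min and 90 s; on this read-out higher numbers stand for weaker inhibition and lower numbers for stronger inhibition.

Compound 2 has the lowest of the two numbers; the step between them is a 1.3-fold lower number from compound 1 to compound 2 (0.12 log units; within the scatter), within the scatter. Compound 3 `C/C(CN(C[C@H]1Cc2ccccc2CN1)[C@H]1CCCc2cccnc21)=C(\F)CN` differs from compound 2 by a group of 6 heavy atoms (4 carbon, 1 nitrogen, 1 fluorine; no ring) in place of a group of 7 heavy atoms (4 carbon, 2 nitrogen, 1 oxygen; no ring), on a saturated chain carbon bound to an amine nitrogen. Among the compounds with values here, only that single step bears on this change, and it shows that swapping the side chain on the saturated chain carbon bound to the amine nitrogen left the read-out essentially unmoved. No step beyond the scatter is therefore expected; compound 3 is estimated at 250 nM (range 80 nM to 800 nM), a step of a 1.2-fold higher number from compound 2 to compound 3 (0.08 log units; within the scatter).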

Compound 3, half-maximal inhibitory concentration: 80 nM
Beside the measured number, compound 3's estimate is 3.1-fold (0.49 log units) above it; low and high end bracket the measured number.
By their numbers in this assay, from the lowest: compound 3; then compounds 2 and 1 (each within the scatter of the next).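

In this assay the group on a saturated chain carbon bound to an amine nitrogen now moves the read-out beyond the scatter: 3-amino-2-fluoro-1-methylprop-1-en-1-yl gives a 2.6-fold lower number from compound 2 to compound 3 (0.42 log units; beyond the scatter), and in place of 4-aminocyclohexyl it gives a 3.5-fold lower number from compound 1 to compound 3 (0.54 log units; beyond the scatter). Both steps are modest, whereas the earlier step between compound 1 and compound 2 stayed within the scatter. Nothing on hand explains these steps. Still open, from the compounds shown here alone, is which part of the 3-amino-2-fluoro-1-methylprop-1-en-1-yl group carries the step, and how a longer chain ending in an amine or a carboxylic acid would read at this place.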